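Methyl added to the pyridyl ring of compound 3

A few compounds are considered here, and "the series" means these few. Any claim that something is new, unique, unknown or untested is made for them only; others in the source may bear on it.

Compound 3 `O=C1NC(=O)C(Cc2ccc(Oc3cc(C(F)(F)F)ccn3)cc2)S1` stands lowest of the three numbers in a functional assay for agonist activity at Free fatty acid receptor 1 (Homo sapiens), read by FLIPR, in the presence of a further agent that is not named here (a higher number here means that more compound is needed for the effect, a lower number that less compound is needed), at 237 nM; compound 2 `O=C1NC(=O)C(Cc2ccc(Oc3cccc(Cl)c3)cc2)S1` gives 318 nM, within the scatter of compound 3, while compound 1 `Cc1ccnc(Oc2ccc(CC3SC(=O)NC3=O)cc2)c1` gives 4280 nM. The measured steps are an 18-fold lower number from compound 1 to compound 3 (1.26 log units; beyond the scatter) and a 13-fold lower number from compound 1 to compound 2 (1.13 log units; beyond the scatter). Compound 4 `Cc1cc(C(F)(F)F)cc(Oc2ccc(CC3SC(=O)NC3=O)cc2)n1` differs from compound 3 by methyl in place of hydrogen on an aromatic carbon. Going by the values given here, the only step that touches this ring swaps methyl for trifluoromethyl, not adding a methyl while keeping the trifluoromethyl; it therefore bears only loosely here. Among the compounds with values here, with no direct precedent, a step within the scatter is expected, a 1.1-fold higher number from compound 3 to compound 4 (0.04 log units; within the scatter). Compound 4 is estimated at 260 nM, with a range from 90 nM to 800 nM.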

Compound 4, half-maximal effective concentration: 218 nM
Estimate against measurement, compound 4: 1.2-fold (0.08 log units) above, and the stated range covers the measured number.
By their numbers in this assay, from the lowest: compounds 4, 3 and 2 (each within the scatter of the next); then compound 1.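

In this assay, going by these compounds alone, the step of a 1.1-fold lower number from compound 3 to compound 4 (0.04 log units; within the scatter) gives the first reading at the aromatic carbon next to the ring nitrogen, and methyl there leaves the number within the scatter of hydrogen. With a trifluoromethyl group on the ring, this carbon therefore accepts a methyl group without a step beyond the scatter. No measured data here account for this result.

Open, from the compounds shown here alone, is whether an ethyl group, a methoxy group or an amine at this carbon would behave the same way. Also open, going by these compounds, is whether methyl here gives a similar step on the methyl-bearing ring of compound 1.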